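Oxadiazole for hydroxyethyl triazole on the shared core

The source may hold more compounds than are shown below. What is called first, only, known or untested is meant among the compounds shown, and "the series" means these compounds.

In a functional assay on K562 cells (Homo sapiens) for inhibition, read by MTT assay, with a stated time of 72 h (on this read-out lower numbers stand for stronger inhibition and higher numbers for weaker inhibition), compound 1 (`Cc1ccc(-n2cc(-c3ccc(C)c(C(F)(F)F)c3)nn2)cc1Nc1nccc(-c2cccnc2)n1`) gives > 30000 nM, which is a limit and not a number; this is the limit of > 30000 nM in this assay, at which 1 of the 2 values shown sits. Within the data shown here, compound 2 (`Cc1ccc(-n2cc(CCO)nn2)cc1Nc1nccc(-c2cccnc2)n1`) gives 10700 nM, the only actual number so far. Among the measured compounds shown here, the one measured step is an at least 2.8-fold lower number from compound 1 to compound 2 (0.44 log units; beyond the scatter), with 2-hydroxyethyl in place of 4-methyl-3-(trifluoromethyl)phenyl. Compound 3 (`Cc1nnc(-c2ccc(C)c(Nc3nccc(-c4cccnc4)n3)c2)o1`) brings (5-methyl-1,3,4-oxadiazol-2-yl in place of 4-(2-hydroxyethyl)-1H-1,2,3-triazol-1-yl on an aromatic carbon), with 5-methyl-1,3,4-oxadiazol-2-yl in place of 4-(2-hydroxyethyl)-1H-1,2,3-triazol-1-yl on an aromatic carbon. The measured step from compound 1 to compound 2 does not cover this exchange, so it sets only a rough scale and no direction. The expected step is a 1.3-fold higher number from compound 2 to compound 3 (0.12 log units; within the scatter), with no change beyond the scatter expected in this assay. The estimate for compound 3 is 14000 nM, with an expected range of 4500 nM to 30000 nM.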

Compound 3, half-maximal inhibitory concentration: > 30000 nM
Compound 3: only a limit was reported; the forecaster's own chance of this, stated with the estimate: 25%; middle value at least 2.1-fold (0.33 log units) from the limit.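

In this assay, the exchange on this aromatic carbon, para to the methyl group, gives an at least 2.8-fold higher number from compound 2 to compound 3 (0.44 log units; beyond the scatter), so this position does respond to the group on it, and 5-methyl-1,3,4-oxadiazol-2-yl does not keep up with 4-(2-hydroxyethyl)-1H-1,2,3-triazol-1-yl. On these data alone, compound 3 gives > 30000 nM, which is a limit and not a number, so the size of the step stays open on one side. Compound 2 remains the only compound with an actual number: the limit of > 30000 nM in this assay, at which 2 of the 3 values shown sit.

Ring and side chain change together here, so the shift cannot be assigned to either one alone. An oxadiazole carrying 2-hydroxyethyl, or a triazole carrying an aminoethyl chain or a carboxylic acid, would separate the two.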